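A few compounds are considered here, and "the series" means these few. Any claim that something is new, unique, unknown or untested is made for them only; others in the source may bear on it.

Working notes on the amide series.

Compound 2 `Cc1ccc(S(=O)(=O)NCc2ccc(CNC(=O)c3ccc(Cl)cc3)cc2)cc1` gives 10 nM in an assay on MDA-MB-231 cells for binding affinity to C-X-C chemokine receptor type 4 (Homo sapiens), read by immunofluorescence and microscopy, with stated times of 10 min and 30 min; a higher number here means that more compound is needed for the effect, a lower number that less compound is needed. It stands level with compound 1 `O=C(NCc1ccc(CNS(=O)(=O)c2ccccc2)cc1)c1cccnc1`, which gives 10 nM, the two together making the lowest of the three numbers in hand; compound 3 `Cc1cccc(C(=O)NCc2ccc(CNS(=O)(=O)c3ccccc3)cc2)c1` gives 1000 nM, the furthest from compound 2. Among the compounds with values here, the one step among the measured compounds sits on the carbonyl carbon: a 100-fold higher number from compound 1 to compound 3 (2.00 log units; beyond the scatter). That step is large and shows the group on the carbonyl carbon matters, though it concerns a different exchange from the one now in question.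

Compound 4 `Cc1ccc(S(=O)(=O)NCc2ccc(CNC(=O)c3c(Cl)cc(Cl)cc3Cl)cc2)cc1` differs from compound 2 in one place: 2,4,6-trichlorophenyl in place of 4-chlorophenyl on a carbonyl carbon. Within the data shown here, no measured pair covers this exchange. Among the measured compounds shown here, the only bearing step, from compound 1 to compound 3, is on the same carbonyl carbon and was large, so a shift beyond the scatter is possible, but its direction is not fixed by the data; compound 1 and compound 2 showing the same number suggests a single change at the same place may also pass without effect.

The expected step is a 3.0-fold higher number from compound 2 to compound 4 (0.48 log units; beyond the scatter). Compound 4 is therefore estimated at 30 nM, in a range from 5 nM to 300 nM.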

Compound 4, effective concentration (reported as EC, without a stated level of effect): 10 nM
Beside the measured number, compound 4's estimate is 3.0-fold (0.48 log units) above it, and the stated range covers the measured number.
By their numbers in this assay, from the lowest: compounds 1, 2 and 4 (each within the scatter of the next); then compound 3.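

In this assay, 2,4,6-trichlorophenyl in place of 4-chlorophenyl on a carbonyl carbon gives no change at the digits printed from compound 2 to compound 4 (within the scatter) and so adds a second reading at this place, where the exchange shown earlier gave a 100-fold higher number from compound 1 to compound 3 (2.00 log units; beyond the scatter) on a different core. An exchange of one carbon-only aromatic ring for another, here with 9 heavy atoms in place of 7, can therefore pass with no visible shift, so a large step is not the rule for every change on this carbonyl carbon. Nothing in hand accounts for the absence of a shift or for the contrast between the two steps.

On these data alone, it remains open whether 3-methylphenyl would give a high number on the core of compound 2, which would separate the effect of the group from that of the core. Also open, as far as these compounds go, is how this place would respond to a phenyl ring carrying an amine or a carboxylic acid in place of chlorine.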